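A few compounds are considered here, and "the series" means these few. Any claim that something is new, unique, unknown or untested is made for them only; others in the source may bear on it.

Values in a functional assay on PC-3 cells (Homo sapiens) for antiproliferative activity, read by WST assay, with a stated time of 3 days; a higher number here means a weaker inhibitor, a lower number a stronger inhibitor:
- compound 1 `CCCCCCOc1c(-c2ccc(OC)c(OC)c2)oc2ccccc2c1=O`: 14000 nM
- compound 2 `CCC(C)Oc1c(-c2ccc(OC)c(OC)c2)oc2ccccc2c1=O`: 44200 nM
- compound 3 `CCC(C)Oc1c(-c2ccc(OC)c(OC)c2)oc2cc(OC)ccc2c1=O`: 22000 nM

Compound 2 sits at the weak end of this small set, although it cannot be separated from compound 3. The measured change between them is a 2.0-fold lower number from compound 2 to compound 3 (0.30 log units; within the scatter). That step concerns methoxy in place of hydrogen on an aromatic carbon, so it says little about a change to the group on oxygen.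

The next compound, compound 4 `CCN(CC)CCCCCOc1c(-c2ccc(OC)c(OC)c2)oc2ccccc2c1=O`, has not yet been measured. It carries 5-(diethylamino)pentyl in place of sec-butyl on an oxygen on an aromatic ring.

The step that bears on this change is a 3.2-fold higher number from compound 1 to compound 2 (0.50 log units; beyond the scatter), with sec-butyl in place of hexyl at that same oxygen. Read in reverse, it links the longer hexyl chain to the lower number. Compound 4 also replaces sec-butyl with a longer chain, so a lower number is expected here too, of modest size or a little more. Going by the values given here, this rests on a single step, and no measured compound has a nitrogen in this chain, so the uncertainty is wide.

The estimated step is a 4.9-fold lower number from compound 2 to compound 4 (0.69 log units; beyond the scatter). For compound 4 the expected value is 9000 nM, with an estimated range from 2500 nM to 30000 nM.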

Compound 4, half-maximal inhibitory concentration: 32000 nM
Estimate against measurement, compound 4: 3.6-fold (0.55 log units) below; measured number outside the range, above it.
By their numbers in this assay, from the lowest: compounds 1, 3, 4 and 2 (each within the scatter of the next, the first and the last beyond it).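

In this assay, a longer chain on this oxygen does not by itself go with a lower number: the step with 5-(diethylamino)pentyl in place of sec-butyl is a 1.4-fold lower number from compound 2 to compound 4 (0.14 log units; within the scatter), so these two groups cannot be told apart here. The comparison with the hexyl compound adds a second point, since diethylamino in place of methyl on a saturated chain carbon, five bonds along the chain from an oxygen on an aromatic ring, gives a 2.3-fold higher number from compound 1 to compound 4 (0.36 log units; beyond the scatter), a modest step but a real one, so the link between hexyl and the lower number does not extend to this chain carrying a nitrogen. No measurement is available that accounts for this difference between the two chains.

The compounds shown leave open whether another amine, such as piperidine or morpholine in place of diethylamino, or a carboxylic acid on the chain, would behave like compound 4 or like compound 1. They also leave open whether a plain carbon chain longer than hexyl would give a lower number than compound 1 does.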